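Longer Bromoalkyl Chain on a Bis-Styryl Core

The source may hold more compounds than are shown below. What is called first, only, known or untested is meant among the compounds shown, and "the series" means these compounds.

Three compounds built on a shared core, each carrying a bromine-terminated chain attached through an oxygen on an aromatic ring, have been tested in a functional assay on A549 cells (Homo sapiens) for cytotoxicity, read by fluorescence and resazurin assay, with a stated time of 48 h; a lower number here means a stronger inhibitor, a higher number a weaker inhibitor. Compound 1 is `COc1cc(/C=C/c2cc(/C=C/c3cc(OC)c(OC)c(OC)c3)nc(OCCCCBr)n2)cc(OC)c1OC`, compound 2 is `COc1ccc(/C=C/c2cc(/C=C/c3ccc(OC)cc3)nc(OCCCCBr)n2)cc1`, and compound 3 is `BrCCCCOc1nc(/C=C/c2ccccc2)cc(/C=C/c2ccccc2)n1`. In this assay compound 1 reaches only a limit, > 20000 nM. In this assay compound 2 likewise gives only a limit, > 20000 nM. In this assay compound 3 also stops at a limit, > 20000 nM. So compound 2 stands where every measured compound stands: at the limit of > 20000 nM in this assay, at which 3 of the 3 values shown sit, with no number beneath it. For the measured compounds named here, no step between measured compounds is available, because none differ in a single place.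

Compound 4 is `COc1ccc(/C=C/c2cc(/C=C/c3ccc(OC)cc3)nc(OCCCCCCBr)n2)cc1`. It differs from compound 2 by 2-bromoethyl in place of bromo on a saturated chain carbon, four bonds along the chain from an oxygen on an aromatic ring. With all three measured compounds sitting at the same limit, the step from compound 2 to compound 4 is expected to be none beyond the scatter, a step that the limit leaves unreadable from compound 2 to compound 4. Compound 4 is therefore expected to give about 30000 nM in this assay, within a range from 15000 nM to 100000 nM.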

Compound 4, half-maximal inhibitory concentration: > 20000 nM
Compound 4: only a limit was reported (the forecaster's own chance of this, stated with the estimate: 85%); the middle value lies beyond the limit too.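

Compound 2 and compound 4 both stop at a limit in this assay, so the step between them cannot be read. The compounds shown leave open whether any change to the chain or the shared core would give an actual number rather than a limit: the limit of > 20000 nM in this assay, at which 4 of the 4 values shown sit.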